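The source may hold more compounds than are shown below. What is called first, only, known or untested is meant among the compounds shown, and "the series" means these compounds.

Measured compounds:
Compound 1 `Cc1nn(-c2ncnc3nc[nH]c23)c2c1C(C(=O)NCc1ccc(F)cc1)CC(=O)N2` – in a functional assay on HEK293 cells for agonist activity at G-protein coupled receptor 39 (Homo sapiens), read by scintillation proximity assay and inositol phosphate accumulation, with a stated time of 75 min, in the presence of a further agent that is not named here (on this read-out higher numbers stand for an effect only at larger amounts of compound and lower numbers for an effect already at smaller amounts), compound 1 gives 4 nM.
Compound 2 `Cc1nn(-c2ncnc3nc[nH]c23)c2c1C(C(=O)NCc1ccccc1)CC(=O)N2` – compound 2 gives 5 nM.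
Compound 3 `Cc1nn(-c2ncnc3nc[nH]c23)c2c1C(OCc1ccc(C(C)C)cc1)CC(=O)N2` – compound 3 gives 5 nM.

Compound 2 stands level with compound 3 at the digits shown, and the two together hold the highest numbers of the three; its nearest neighbour is compound 3, with no change at the digits shown, and its furthest lies at a 1.3-fold higher number from compound 1 to compound 2 (0.10 log units; within the scatter), within the scatter. Compound 4 `Cc1nn(-c2ncnc3nc[nH]c23)c2c1C(c1ccc(F)cc1Cl)CC(=O)N2` differs from compound 2 by 2-chloro-4-fluorophenyl in place of benzylcarbamoyl on a saturated ring carbon. Within the data shown here, the single measured step, from compound 1 to compound 2, alters only a substituent on the aromatic ring of the benzylcarbamoyl group and stays within the scatter; compound 3, with a different link to its aromatic ring, sits level with compound 2. No measured step removes the benzylcarbamoyl group altogether and places an aromatic ring directly on the saturated ring carbon, so the change in compound 4 is untested among these compounds. The range is therefore wide. Compound 4 is expected to give 20 nM, between 4 nM and 150 nM, which would be a step of a 4.0-fold higher number from compound 2 to compound 4 (0.60 log units; beyond the scatter) toward higher numbers.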

Compound 4, half-maximal effective concentration: 9 nM
Beside the measured number, compound 4's estimate is 2.2-fold (0.35 log units) above it, and the stated range covers the measured number.
By their numbers in this assay, from the lowest: compounds 1, 2, 3 and 4 (each within the scatter of the next, the first and the last beyond it).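

Among these compounds, at the saturated ring carbon, 2-chloro-4-fluorophenyl, with 0 hydrogen-bond donors and 0 hydrogen-bond acceptors, takes the place of benzylcarbamoyl and sets an aromatic ring directly on that carbon, which comes out as a 1.8-fold higher number from compound 2 to compound 4 (0.26 log units; within the scatter) in this assay and is the first measured step here to remove the benzylcarbamoyl group altogether. For this pair, the carbonyl and the amide hydrogen of benzylcarbamoyl are thus not needed to keep the number within the scatter of compound 2. Nothing available offers an explanation for this outcome.

The compounds shown leave open whether the chloro or the fluoro of 2-chloro-4-fluorophenyl matters to the number, as a plain phenyl or a 4-fluorophenyl on the same carbon would tell. Also open, from the compounds shown here alone, is how this position responds to a non-aromatic group such as a carboxylic acid, an amine or a cyclohexyl ring.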